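Swapping the acyl group on a shared core

The compounds below may be only part of what the source reports. "The series", "measured", "known", "first", "only" and "open" are said of these compounds alone.

- Compound 1 `COc1ccc(/C=C/C(=O)c2ccc(OC)c3c2OC(C)(C)C=C3)cc1O`: 630 nM
- Compound 2 `C=CCOc1cc(/C=C/C(=O)c2ccc(OC)c3c2OC(C)(C)C=C3)ccc1OC`: > 10000 nM (a limit, not a number)
- Compound 3 `COc1ccc(/C=C/C(=O)Oc2cc(/C=C/C(=O)c3ccc(OC)c4c3OC(C)(C)C=C4)ccc2OC)cc1`: 380 nM

These values come from a functional assay on K562 cells (Homo sapiens) for cytotoxicity, read by MTT assay; on this read-out lower numbers stand for stronger inhibition and higher numbers for weaker inhibition. Compound 3 stands level with compound 1, and a 1.7-fold lower number from compound 1 to compound 3 (0.22 log units; within the scatter) shows no real separation. Compound 2 has only a limit, so it gives no exact value.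

Compound 4 `COc1ccc(/C=C/C(=O)c2ccc(OC)c3c2OC(C)(C)C=C3)cc1OC(=O)c1ccco1` differs from compound 3 on a carbonyl carbon, with furan-2-yl in place of 2-(4-methoxyphenyl)ethenyl on a carbonyl carbon.

Two measured steps show that the group on this oxygen can matter: allyl in place of hydrogen gave an at least 15-fold higher number from compound 1 to compound 2 (1.20 log units; beyond the scatter), and the acyl group of compound 3 in place of allyl gave an at least 26-fold lower number from compound 2 to compound 3 (1.42 log units; beyond the scatter). The closest guide is the acyl group in place of hydrogen, a 1.7-fold lower number from compound 1 to compound 3 (0.22 log units; within the scatter), which stayed within the scatter. A swap inside that acyl group is therefore expected to produce no step beyond the scatter in this assay, although the allyl result argues for a wide range.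

The expected change is a 1.6-fold higher number from compound 3 to compound 4 (0.20 log units; within the scatter).

The estimated value for compound 4 is 600 nM, with an expected range from 200 nM to 3000 nM.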

Compound 4, half-maximal inhibitory concentration: 450 nM
The estimate for compound 4 lay 1.3-fold (0.12 log units) above the measured number; measured number inside the range.
By their numbers in this assay, from the lowest: compounds 3, 4 and 1 (each within the scatter of the next). At a limit, above all of these: compound 2.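

Replacing 2-(4-methoxyphenyl)ethenyl with furan-2-yl on the carbonyl carbon gave a 1.2-fold higher number from compound 3 to compound 4 (0.07 log units; within the scatter), so a single five-membered aromatic ring serves here as well as the larger group with its six-membered aromatic ring and double bond. The (furan-2-yl)carbonyl group in place of hydrogen on the oxygen gave a 1.4-fold lower number from compound 1 to compound 4 (0.15 log units; within the scatter), while in place of allyl it gave an at least 22-fold lower number from compound 2 to compound 4 (1.34 log units; beyond the scatter), so the two acyl groups and hydrogen stay level and allyl alone goes against that pattern. Compound 2 carries a limit, not a number: the limit of > 10000 nM in this assay, at which 1 of the 4 values shown sits.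

On these data alone, it remains open whether a methyl group on this oxygen would behave like allyl or like hydrogen. As far as these compounds go, it is also open whether an acetyl group, with no ring at all, or an amine at the end of a longer chain would stay level with the acyl groups.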